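Pyrazolyl in place of propylamino on a benzamide

The source may hold more compounds than are shown below. What is called first, only, known or untested is meant among the compounds shown, and "the series" means these compounds.

Compound 1 `CCCNc1ccc(C(=O)N2CCCCc3ccccc32)c(Cl)c1`: 18 nM
Compound 2 `O=C(c1ccc(N2CCCC2)cc1)N1CCCCc2ccccc21`: 1000 nM

In an assay on HeLa cells for binding affinity to Vasopressin V2 receptor (Homo sapiens) (a lower number here means a stronger inhibitor, a higher number a weaker inhibitor), compound 1 gives 18 nM, the lowest of the two numbers recorded. Its nearest neighbour, compound 2, gives 1000 nM, a gap that lies beyond the scatter; the two compounds differ in more than one place, so nothing is drawn from that pair beyond what the two values show.

Compound 3 `O=C(c1ccc(-n2cccn2)cc1Cl)N1CCCCc2ccccc21` has not yet been measured in this assay. It differs from compound 1 by 1H-pyrazol-1-yl in place of propylamino on an aromatic carbon. Among the compounds with values here, no single-change step between measured compounds exists here to set the size of such a replacement, so the expectation rests on compound 1 alone. The replacement is expected to cost some affinity, with the step from compound 1 to compound 3 estimated at a 3.3-fold higher number from compound 1 to compound 3 (0.52 log units; beyond the scatter), modestly beyond the scatter toward a higher number. For compound 3 the expected value is 60 nM, within a range of 12 nM to 400 nM.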

Compound 3, half-maximal inhibitory concentration: 8.8 nM
Compound 3: the middle estimate sits 6.8-fold (0.83 log units) above what was measured, outside the stated range (below it).
By their numbers in this assay, from the lowest: compound 3; then compound 1; then compound 2.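

In this assay, 1H-pyrazol-1-yl in place of propylamino on the aromatic carbon para to a large group gives a 2.0-fold lower number from compound 1 to compound 3 (0.31 log units; beyond the scatter), a modest step in favour of the ring. In this pair, then, the position keeps its affinity when a chain with a hydrogen-bond donor gives way to a five-membered aromatic ring with 0 hydrogen-bond donors, so that donor is not required here. Nothing measured on these compounds accounts for the step.

Compound 2 differs from compound 1 and compound 3 in more than one place, so the part played by the chloro group cannot be read from it. The compounds shown also leave open how an imidazole, a triazole, a phenyl ring or a shorter chain such as ethylamino would fare at this position.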